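The source may hold more compounds than are shown below. What is called first, only, known or untested is meant among the compounds shown, and "the series" means these compounds.

In an ADME assay on liver for metabolic stability, with Liver microsome (Homo sapiens) as the target, read by LC-MS, using microsomes (on this read-out higher numbers stand for fast clearance and lower numbers for slow clearance), three compounds have been measured so far. Compound 1 `O=C(NCc1cc(Cl)ccc1-n1cnnn1)[C@@H]1C[C@@H]2C[C@@H]2N1C(=O)[C@H](O)C1CCCCC1` gives 150 mL.min-1.g-1, compound 2 `CCCC[C@@H](O)C(=O)N1C[C@H]2C[C@H]2[C@H]1C(=O)NCc1cc(Cl)ccc1-n1cnnn1` gives 32 mL.min-1.g-1 and compound 3 `CC(C)(C)C[C@@H](O)C(=O)N1CC[C@@H]2C[C@@]21C(=O)NCc1cc(Cl)ccc1-n1cnnn1` gives 27 mL.min-1.g-1. Compound 2 therefore sits level with compound 3 within the usual scatter, and clearly under compound 1. Compound 4 `O=C(NCc1cc(Cl)ccc1-n1cnnn1)[C@@H]1[C@@H]2C[C@@H]2CN1C(=O)[C@H](O)c1ccccc1F` has not yet been measured, and it differs from compound 2 as follows: 2-fluorophenyl in place of butyl on a saturated chain carbon bound to a carbonyl carbon and an oxygen on a saturated carbon. This puts 2-fluorophenyl in place of butyl. Within the data shown here, no measured pair shows this change alone, so any forecast is rough. The expected step is a 1.3-fold higher number from compound 2 to compound 4 (0.10 log units; within the scatter), a slight rise that stays within the scatter. The upper end is left wide, as compound 1 reaches 150 mL.min-1.g-1. For compound 4 the estimated value is 40 mL.min-1.g-1, with an expected range from 15 mL.min-1.g-1 to 100 mL.min-1.g-1.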

Compound 4, intrinsic clearance in microsomes: < 12 mL.min-1.g-1
Compound 4 gave a limit, no number; the forecaster's own chance of this, stated with the estimate: 3%; middle value at least 3.3-fold (0.52 log units) from the limit.
By their numbers in this assay, from the lowest: compounds 3 and 2 (each within the scatter of the next); then compound 1. At a limit, below all of these: compound 4.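

Replacing butyl with 2-fluorophenyl on a saturated chain carbon bound to a carbonyl carbon and an oxygen on a saturated carbon gives an at least 2.6-fold lower number from compound 2 to compound 4 (0.42 log units; beyond the scatter) in this assay. Among these compounds, the earlier compounds offered no single change, so this is the first sign that the group at this position alone can shift clearance beyond the scatter. Compound 4 gives a limit, not a number: the limit of < 12 mL.min-1.g-1 in this assay, at which 1 of the 4 values shown sits.

Going by these compounds, the full size of the step stays open. So does whether the fluorine or the ring carries it, and how an unsubstituted phenyl or an amine would read at this position.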